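Amide variation on the carbonyl carbon of the shared core

The compounds below may be only part of what the source reports. "The series", "measured", "known", "first", "only" and "open" are said of these compounds alone.

Three compounds share one core and differ only on the carbonyl carbon. In an assay on CHO cells for displacement of a labelled ligand from histamine receptor H3 (Macaca mulatta) (on this read-out higher numbers stand for weaker inhibition and lower numbers for stronger inhibition), compound 1 `Cc1cc(NC(=O)C2CC3CCC2C3)ccc1N1CCC(N2CCCC2C)C1` gives 130 nM, compound 2 `Cc1cc(NC(=O)C2CC2)ccc1N1CCC(N2CCCC2C)C1` gives 17.7 nM, and compound 3 `Cc1cc(NC(=O)C2CCCO2)ccc1N1CCC(N2CCCC2C)C1` gives 17 nM. Compound 3 holds the lowest of the three numbers, though compound 2 sits within the scatter of it; compound 1 stands apart, with a 7.6-fold lower number from compound 1 to compound 3 (0.88 log units; beyond the scatter) and a 7.3-fold lower number from compound 1 to compound 2 (0.87 log units; beyond the scatter), while a 1.0-fold lower number from compound 2 to compound 3 (0.02 log units; within the scatter) stays within the scatter.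

Compound 4 `CC(=O)N1CCCC1C(=O)Nc1ccc(N2CCC(N3CCCC3C)C2)c(C)c1` is not yet measured. It differs from compound 3 by 1-acetylpyrrolidin-2-yl in place of oxolan-2-yl on a carbonyl carbon. The two steps from compound 1 show that a smaller group on the carbonyl carbon went with a lower number; compound 4 instead enlarges the group. A modest rise is therefore expected, a 2.1-fold higher number from compound 3 to compound 4 (0.31 log units; beyond the scatter), smaller than the steps from compound 1. Compound 4 is estimated at 35 nM, with a range of 12 nM to 100 nM.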

Compound 4, inhibition constant: 44.9 nM
Compound 4: the middle estimate sits 1.3-fold (0.11 log units) below what was measured; low and high end bracket the measured number.
By their numbers in this assay, from the lowest: compounds 3 and 2 (each within the scatter of the next); then compound 4; then compound 1.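

Moving from oxolan-2-yl to 1-acetylpyrrolidin-2-yl on this carbonyl carbon gives a 2.6-fold higher number from compound 3 to compound 4 (0.42 log units; beyond the scatter) and, against cyclopropyl, a 2.5-fold higher number from compound 2 to compound 4 (0.40 log units; beyond the scatter) on the same read-out. Heavy-atom count alone does not order the series, and compound 4 goes against it: its 1-acetylpyrrolidin-2-yl group, the larger by that count, gives a 2.9-fold lower number from compound 1 to compound 4 (0.46 log units; beyond the scatter) relative to the carbon-only group of 7 heavy atoms. No supporting data explain these steps.

Whether the acetyl or the ring accounts for the rise stays open, and an unacetylated pyrrolidin-2-yl amine would separate the two. On these data alone, how a carboxylic acid or an open butyl chain would read on this carbonyl carbon also stays open.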